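One carbon less on the chain of compound 2

A few compounds are considered here, and "the series" means these few. Any claim that something is new, unique, unknown or untested is made for them only; others in the source may bear on it.

Three compounds share one core and differ only in the group carried by the amide-type nitrogen. Compound 1 `Cc1nc(N)sc1CCCN/C(N)=N/C(=O)NC(C)c1ccc(Br)cc1` gives 30.2 nM in an assay on membranes from Sf9 cells for displacement of a labelled ligand from histamine H2 receptor (Homo sapiens), read by scintillation counting, with a stated time of 60 min; a higher number here means a weaker inhibitor, a lower number a stronger inhibitor. Compound 2 `CCCCCCNC(=O)/N=C(\N)NCCCc1sc(N)nc1C` gives 28.8 nM in this assay, and compound 3 `Cc1nc(N)sc1CCCN/C(N)=N/C(=S)N[C@H](C)c1ccccc1` gives 115 nM in this assay. Compound 2 thus stands at the lowest of the three numbers, but its number and that of compound 1 lie within the scatter of each other, so no order between these two can be read; only compound 3 stands apart, beyond the scatter.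

Compound 4 `CCCCCNC(=O)/N=C(\N)NCCCc1sc(N)nc1C` has not yet been measured. It differs from compound 2 by hydrogen in place of methyl on a saturated chain carbon, five bonds along the chain from an amide-type nitrogen. Going by the values given here, no measured pair shows this exact step, so its size cannot be taken from the data. A change of this kind is expected to give no step beyond the scatter in this assay, in either direction. Compound 4 is therefore expected to give about 35 nM in this assay, with a range from 14 nM to 85 nM. The step of a 1.2-fold higher number from compound 2 to compound 4 (0.08 log units; within the scatter) is expected to be small.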

Compound 4, inhibition constant: 4.47 nM
For compound 4 the middle estimate is 7.8-fold (0.89 log units) above the measured one; the measured number lies below the stated range.
By their numbers in this assay, from the lowest: compound 4; then compounds 2 and 1 (each within the scatter of the next); then compound 3.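

In this assay, hydrogen in place of methyl on a saturated chain carbon, five bonds along the chain from an amide-type nitrogen, gives a 6.4-fold lower number from compound 2 to compound 4 (0.81 log units; beyond the scatter). The earlier compounds shown here differed from one another in more than one place, so they could not isolate any single change; this pair shows that the number at this position responds clearly to the loss of a single methyl, even though the chain itself remains and the rest of the structure is unchanged. No measurement shown here gives a reason for the size of this step or tells what the methyl does at this position.

The compounds shown rest on this one pair, so they leave open whether the number would keep falling with a butyl chain on the same nitrogen, or rise again, and so whether the pentyl chain of compound 4 marks a best length or only a point along a trend. They also leave open how a hydroxyl group or a cyclopentyl ring would read at this place, and whether the same step would appear on a thiocarbonyl compound such as compound 3.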